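The source may hold more compounds than are shown below. What is called first, only, known or untested is meant among the compounds shown, and "the series" means these compounds.

Measured compounds: compound 1 `COc1cc(OC)c(OC)cc1/C=C/C(=O)c1ccc(O)cc1O` with 34800 nM; compound 2 `COc1ccc(/C=C/C(=O)c2ccc(O)cc2O)cc1` with "not determined" (no result reported).

For the measured compounds named here, compound 1 `COc1cc(OC)c(OC)cc1/C=C/C(=O)c1ccc(O)cc1O` is the only compound with a number in a functional assay on A375-C5 cells (Homo sapiens) for inhibition, read by sulforhodamine B assay, with a stated time of 48 h (on this read-out higher numbers stand for weaker inhibition of growth and lower numbers for stronger inhibition of growth), where compound 1 gives 34800 nM. Compound 2 `COc1ccc(/C=C/C(=O)c2ccc(O)cc2O)cc1` was also tested but no result was reported in this assay, so compound 1 stands alone. Compound 3 `CCCc1c(O)ccc(C(=O)/C=C/c2cc(OC)c(OC)cc2OC)c1O` differs from compound 1 by propyl in place of hydrogen on an aromatic carbon. Going by the values given here, with no comparable step among the measured compounds, the change is expected to lie within the scatter or to be a small gain, giving a 1.4-fold lower number from compound 1 to compound 3 (0.14 log units; within the scatter). Compound 3 is therefore estimated at 25000 nM, between 8000 nM and 80000 nM.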

Compound 3, concentration for 50% growth inhibition: 23000 nM
Compound 3: the middle estimate sits 1.1-fold (0.04 log units) above what was measured; measured number inside the range.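

Propyl in place of hydrogen on an aromatic carbon, ortho to two hydroxy groups, gives a 1.5-fold lower number from compound 1 to compound 3 (0.18 log units; within the scatter) in this assay and so leaves the number indistinguishable from that of compound 1. For the compounds shown here, this is the first step that can be read here, and it shows that this position takes a propyl chain without a change beyond the scatter. Nothing available gives a reason for this result.

From the compounds shown here alone, whether a longer chain such as hexyl, an amine or a carboxylic acid at this position would move the number beyond the scatter remains open.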